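Working notes: from compound 2 to compound 3

The source may hold more compounds than are shown below. What is called first, only, known or untested is meant among the compounds shown, and "the series" means these compounds.

compound 1 `CN(C)CCn1c(N)c(-c2nc3ccccc3[nH]2)c2nc(C#N)c(C#N)nc21`: 43500 nM
compound 2 `CN1CCN(CCCn2c(N)c(-c3nc4ccccc4[nH]3)c3nc(C#N)c(C#N)nc32)CC1`: 4520 nM

In a functional assay on cells (Homo sapiens) for antiproliferative activity, read by MTT assay, with a stated time of 48 h (on this read-out lower numbers stand for stronger inhibition and higher numbers for weaker inhibition), compound 2 holds the lower of the two measured numbers, at 4520 nM. Compound 3 `N#Cc1nc2c(-c3nc4ccccc4[nH]3)c(N)n(CCCO)c2nc1C#N` keeps the shared core and alters the end of the chain: hydroxy in place of 4-methylpiperazin-1-yl on a saturated chain carbon, three bonds along the chain from an aromatic nitrogen. The 3-(4-methylpiperazin-1-yl)propyl group thus gives way to 3-hydroxypropyl. Among the measured compounds shown here, one measured step bears on this, a 9.6-fold lower number from compound 1 to compound 2 (0.98 log units; beyond the scatter), a modest step beyond the scatter. For the measured compounds named here, it is only a rough guide, since it replaces one amine-bearing chain end with another, and no compound with a hydroxy end has been measured. Going by a 9.6-fold lower number from compound 1 to compound 2 (0.98 log units; beyond the scatter), a modest move to a higher number is expected in this assay. The expected step is a 4.0-fold higher number from compound 2 to compound 3 (0.60 log units; beyond the scatter). For compound 3 the estimate is 18000 nM, with an expected range of 6000 nM to 55000 nM.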

Compound 3, half-maximal inhibitory concentration: > 50000 nM
Compound 3 ended at the assay's limit; the forecaster's own chance of this, stated with the estimate: 10%; at least 2.7-fold (0.44 log units) between middle value and limit.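

In this assay, compound 3 stands at a limit and not at a number: the limit of > 50000 nM in this assay, at which 1 of the 3 values shown sits. On the propyl chain, hydroxy in place of 4-methylpiperazin-1-yl gives an at least 11-fold higher number from compound 2 to compound 3 (1.04 log units; beyond the scatter), so this chain end is not interchangeable with the piperazine end, whereas the earlier pair compared only one amine-bearing end with another. The comparison with the dimethylamino chain gives an at least 1.1-fold higher number from compound 1 to compound 3 (0.06 log units; that floor lies within the scatter), and this floor alone sets no order between the two compounds.

The compounds shown leave open whether the lower number of compound 2 goes with the 4-methylpiperazin-1-yl ring or with an amine end of any kind on the propyl chain. From the compounds shown here alone, how a 3-(dimethylamino)propyl or a 3-(morpholin-4-yl)propyl group would stand in this assay remains open, and either would help to separate the two readings.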